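The source may hold more compounds than are shown below. What is called first, only, known or untested is meant among the compounds shown, and "the series" means these compounds.

In a functional assay on GBM3 cells (Homo sapiens) for antiproliferative activity, read by WST assay, with a stated time of 72 h (a higher number here means a weaker inhibitor, a lower number a stronger inhibitor), compound 1 (`O=C(Nc1ccc(C(F)(F)F)cc1)Nc1cc2ncncc2cc1OCc1cccc(F)c1`) gives 6300 nM and compound 2 (`O=C(Nc1ccc(C(F)(F)F)cc1)Nc1cc2ncncc2cc1OCc1cccc(Cl)c1`) gives 5100 nM with the two level within the scatter, while compound 3 (`O=C(Nc1cc2ncncc2cc1OCc1ccccc1Cl)Nc1cccc2ccccc12`) gives 2700 nM as a number lower than that of compound 1 by more than the scatter. Compound 4 (`O=C(Nc1ccccc1F)Nc1cc2ncncc2cc1OCc1cccc(F)c1`) is not yet measured and carries 2-fluorophenyl in place of 4-(trifluoromethyl)phenyl on an amide-type nitrogen, with the rest of compound 1 unchanged. Within the data shown here, the one measured step (a 1.2-fold lower number from compound 1 to compound 2 (0.09 log units; within the scatter)) is chloro in place of fluoro on an aromatic carbon and leaves that nitrogen untouched. Compound 3 differs from compound 1 in more than one place and isolates no single change. Among the measured compounds shown here, no measured step therefore speaks directly to this change, and in this assay no shift beyond the scatter is expected in either direction. The expected step (a 1.1-fold lower number from compound 1 to compound 4 (0.02 log units; within the scatter)) is an estimate resting on this lack of evidence. For compound 4 the estimated value is 6000 nM with an expected range from 2500 nM to 14000 nM in this read-out.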

Compound 4, half-maximal inhibitory concentration: 8100 nM
For compound 4 the middle estimate is 1.4-fold (0.13 log units) below the measured one; the measured number falls inside the stated range.
By their numbers in this assay, from the lowest: compounds 3, 2, 1 and 4 (each within the scatter of the next, the first and the last beyond it).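

In this assay, among these compounds, the first single-place reading at the amide-type nitrogen gives a 1.3-fold higher number from compound 1 to compound 4 (0.11 log units; within the scatter), a step within the scatter for 2-fluorophenyl in place of 4-(trifluoromethyl)phenyl. This position, which the earlier chloro for fluoro step left untouched, therefore accepts this exchange of a group of 10 heavy atoms for one of 7 without a shift beyond the scatter. Nothing at hand accounts for the number holding level across this change.

This single step swaps one substituted ring for another, so it does not separate the loss of trifluoromethyl from the gain of fluoro. The compounds shown also leave open how an unsubstituted phenyl, a ring carrying an amine or a carboxylic acid, or a saturated group such as cyclohexyl would read on this nitrogen.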